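Alkynyl-pyridine series: methyl to chloro on the phenyl ring

The source may hold more compounds than are shown below. What is called first, only, known or untested is meant among the compounds shown, and "the series" means these compounds.

Measured so far:
compound 1, `O=C(NC1CCCC1)c1ccc(C#Cc2ccccc2)nc1`; in an assay on HEK293 cells for displacement of a labelled ligand from metabotropic glutamate receptor 5 (Homo sapiens), with a stated time of 2 h (on this read-out lower numbers stand for stronger inhibition and higher numbers for weaker inhibition), compound 1 gives 3300 nM.
compound 2, `O=C(NC1CCCC1)c1ccc(C#Cc2cccnc2)nc1`; for compound 2 this assay reports only a limit, > 32000 nM.
compound 3, `Cc1cccc(C#Cc2ccc3c(n2)CCN(C)C3=O)c1`; in this assay compound 3 gives 820 nM.

Compound 3 stands lowest of the two numbers reported; the nearest is compound 1, whose number is higher beyond the scatter. The remaining value is a limit, (the limit of > 32000 nM in this assay, at which 1 of the 3 values shown sits), so compound 2 cannot be ranked against compound 3. Among the measured compounds shown here, the only measured step, an at least 9.6-fold higher number from compound 1 to compound 2 (0.98 log units; beyond the scatter), concerns the replacement of phenyl by pyridin-3-yl on the triple-bonded carbon, a change of a different kind.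

Compound 4, `CN1CCc2nc(C#Cc3cccc(Cl)c3)ccc2C1=O`, differs from compound 3 by chloro in place of methyl on an aromatic carbon, meta to a large group. For the measured compounds named here, no measured step bears on this exchange; the one step available does not match it. The expectation is therefore a step of a 1.4-fold lower number from compound 3 to compound 4 (0.14 log units; within the scatter) that stays within the scatter, in no firm direction. Compound 4 is estimated at 600 nM, with a range from 200 nM to 2000 nM.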

Compound 4, inhibition constant: 250 nM
Estimate against measurement, compound 4: 2.4-fold (0.38 log units) above; the measured number falls inside the stated range.
By their numbers in this assay, from the lowest: compound 4; then compound 3; then compound 1. At a limit, above all of these: compound 2.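

In this assay, chloro in place of methyl on an aromatic carbon, meta to a large group, gives a 3.3-fold lower number from compound 3 to compound 4 (0.52 log units; beyond the scatter), so the series responds to a change at this position of the phenyl ring. The earlier step changed the ring itself, from phenyl to pyridin-3-yl, whereas this one keeps the ring and changes only the group on it, and it runs toward the lower number. No measured property shown here accounts for this step.

From the compounds shown here alone, whether other groups at this position, such as fluoro, methoxy or an amine, go beyond chloro remains open, as does the effect of chloro elsewhere on the ring. Also open, going by these compounds, is whether 3-chlorophenyl gives a comparable result on the core of compound 1.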